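A few compounds are considered here, and "the series" means these few. Any claim that something is new, unique, unknown or untested is made for them only; others in the source may bear on it.

Compound 1, `O=C(Nc1cccc(-c2nc3ccccc3s2)c1)c1cnccc1Cl`: 12000 nM
Compound 2, `O=C(Nc1cccc(-c2nc3ccccc3s2)c1)c1cccnc1Cl`: > 25000 nM, a limit of the assay
Compound 3, `O=C(Nc1cccc(-c2nc3ccccc3s2)c1)c1ccnc(Cl)c1`: > 25000 nM, a limit of the assay

In an ADME assay on Raji cells (Homo sapiens) for inhibition, with a stated time of 72 h (on this read-out higher numbers stand for an effect only at larger amounts of compound and lower numbers for an effect already at smaller amounts), compound 1 gives 12000 nM. For compound 2 the value > 25000 nM is a limit of the assay and not a number. For compound 3 the value > 25000 nM is likewise a limit. For the measured compounds named here, compound 1 thus carries the only real number in this set, the other two values sitting at the limit of > 25000 nM in this assay, at which 2 of the 3 values shown sit. The two readable steps, an at least 2.0-fold higher number from compound 1 to compound 2 (0.31 log units; beyond the scatter) and an at least 2.0-fold higher number from compound 1 to compound 3 (0.31 log units; beyond the scatter), each exchange one chloropyridinyl group for another on the carbonyl carbon; the step between compound 2 and compound 3 stays unreadable, since both values are limits.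

Compound 4, `Cc1ccc(-c2nc3ccccc3s2)cc1NC(=O)c1cnccc1Cl`, differs from compound 1 at another place: methyl in place of hydrogen on an aromatic carbon. Going by the values given here, none of the measured steps touches this part of the shared core, so no measured step bears directly on the change. Without such guidance, the step from compound 1 to compound 4 is expected to be none beyond the scatter, no change at the digits printed from compound 1 to compound 4 (within the scatter). Compound 4 is accordingly estimated at 12000 nM, with a range from 4000 nM to 30000 nM.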

Compound 4, half-maximal effective concentration: > 25000 nM
Compound 4: a limit, no number; the forecaster's own chance of this, stated with the estimate: 30%; middle value at least 2.0-fold (0.31 log units) away from the limit.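

In this assay compound 4 gives > 25000 nM, which is a limit of the assay and not a number. Even so, methyl in place of hydrogen on an aromatic carbon, ortho to a large group, gives an at least 2.0-fold higher number from compound 1 to compound 4 (0.31 log units; beyond the scatter), so this part of the shared core, which the earlier steps left untouched, responds to the addition of a single carbon. Only the least possible size of this step can be read, and compound 1 remains the only compound here with a real number: the limit of > 25000 nM in this assay, at which 3 of the 4 values shown sit.

From the compounds shown here alone, whether a fluorine atom, a methoxy group or an amine at this same place would keep the value of compound 1 stays open. Also open, going by these compounds, is how far compound 4 lies past its limit, and so how large the effect of the methyl really is.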